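The source may report more compounds than this note shows. Statements on the series, on what has been measured and on what is new or still open speak of the compounds shown alone.

Measured compounds:
- compound 1: `CC(=O)N[C@@H](CSCC=C(C)C)C(=O)C=[N+]=[N-]` — > 100000 nM
- compound 2: `CC(=O)N[C@@H](CSC/C=C(\C)CCC=C(C)C)C(=O)CCl` — > 100000 nM

In a functional assay on NALM-6 cells (Homo sapiens) (on this read-out lower numbers stand for stronger inhibition and higher numbers for weaker inhibition), compound 1, `CC(=O)N[C@@H](CSCC=C(C)C)C(=O)C=[N+]=[N-]`, reaches only a limit of the assay, > 100000 nM. Compound 2, `CC(=O)N[C@@H](CSC/C=C(\C)CCC=C(C)C)C(=O)CCl`, likewise gives only a limit in this assay, > 100000 nM. So compound 2 stands at the same place as every other value shown: neither measured compound displays inhibition that the assay could put a number on, and both sit at the limit of > 100000 nM in this assay, at which 2 of the 2 values shown sit.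

Compound 3, `CC(=O)N[C@@H](CSCC=C(C)C)C(=O)CCl`, differs from compound 2 in one place: hydrogen in place of 3-methylbut-2-en-1-yl on a saturated chain carbon bound to a double-bonded chain carbon. For the measured compounds named here, no pair of measured compounds differs in just one place, so no measured step guides the expectation; the only evidence is that both measured compounds sit at the limit of > 100000 nM in this assay, at which 2 of the 2 values shown sit. The expectation is therefore that compound 3 most likely also reaches only the limit, with no step beyond the scatter from compound 2 expected in this assay. The estimate for compound 3 is 100000 nM, with a range of 30000 nM to 300000 nM, which means an expected step of a number no higher from compound 2 to compound 3 (the limit leaves the size open).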

Compound 3, half-maximal inhibitory concentration: 12600 nM
For compound 3 the middle estimate is 7.9-fold (0.90 log units) above the measured one; measured number below the stated range.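

In this assay, compound 3 is the only one of the three that gives a measured number, 12600 nM, so this series can now show inhibition that the assay can put a figure on. Hydrogen in place of 3-methylbut-2-en-1-yl, on a saturated chain carbon bound to a double-bonded chain carbon, gives an at least 7.9-fold lower number from compound 2 to compound 3 (0.89 log units; beyond the scatter), which shows that this 5-carbon group is not needed for the inhibition seen here and that the series does better in this assay without it. A change at a second place matters as well: a group of 2 heavy atoms (1 carbon, 1 chlorine) in place of a group of 3 heavy atoms (1 carbon, 2 nitrogen), on a carbonyl carbon, gives an at least 7.9-fold lower number from compound 1 to compound 3 (0.89 log units; beyond the scatter).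

From the compounds shown here alone, the true size of each step stays open, because each starts from a compound that reaches only a limit: the limit of > 100000 nM in this assay, at which 2 of the 3 values shown sit. Going by these compounds, it is also open how a single methyl group would behave at the chain carbon, or whether a bromine in place of the chlorine would keep the inhibition of compound 3.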